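The source may hold more compounds than are shown below. What is called first, only, known or untested is meant among the compounds shown, and "the series" means these compounds.

Measured compounds:
Compound 1 `N/C(=N/O)c1ccc(C2=C(S(=O)(=O)c3ccc(F)cc3)CC(c3ccccc3)(c3ccccc3)O2)cc1` gives 10200 nM in an ADME assay on J774.A1 cells (Mus musculus) for cytotoxicity, read by MTT assay, with a stated time of 72 h; a lower number here means that less compound is tolerated, a higher number that more compound is tolerated.
Compound 2 `CC1(c2ccc(-c3ccc(/C(N)=N\O)cc3)cc2)CC(S(=O)(=O)c2ccc(F)cc2)=C(c2ccc(/C(N)=N\O)cc2)O1` gives 3940 nM in this assay.
Compound 3 `CC1(Cc2ccccc2)CC(S(=O)(=O)c2ccccc2F)=C(c2ccc(/C(N)=N\O)cc2)O1` gives 29100 nM in this assay.

Among the three measured compounds, compound 2 stands at the lowest number in this assay, meaning that the least compound is tolerated. Its nearest neighbour is compound 1, whose value lies beyond the scatter above it, and compound 3 lies further still, also beyond the scatter. No pair of these compounds differs in a single place, so no step between them can be read directly.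

Compound 4 `CC1(c2ccc(-c3ccncc3)cc2)CC(S(=O)(=O)c2ccc(F)cc2)=C(c2ccc(/C(N)=N\O)cc2)O1` has not yet been measured. It differs from compound 2 in one place: a group of 6 heavy atoms (5 carbon, 1 nitrogen; one six-membered aromatic ring with 1 hetero atom) in place of a group of 10 heavy atoms (7 carbon, 2 nitrogen, 1 oxygen; one six-membered aromatic ring of carbon only), on an aromatic carbon. The group that leaves carries the same kind of end group that all three measured compounds retain on the other side of the shared core; compound 4 keeps only one of them.

The two compounds carrying a single such group, compound 1 and compound 3, both sit at higher numbers than compound 2, so a moderate increase is expected from compound 2 to compound 4 , on the order of a 1.9-fold higher number from compound 2 to compound 4 (0.28 log units; within the scatter), probably just beyond the scatter but not reaching compound 3. Compound 4 is therefore estimated at 7500 nM, within a range from 2500 nM to 22000 nM.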

Compound 4, half-maximal cytotoxic concentration: 6750 nM
For compound 4 the middle estimate is 1.1-fold (0.05 log units) above the measured one, within the range that was stated.
By their numbers in this assay, from the lowest: compounds 2, 4 and 1 (each within the scatter of the next, the first and the last beyond it); then compound 3.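

In this assay, among these compounds, the exchange on this aromatic carbon, para to a large group, provides the first step that can be read directly: pyridin-4-yl in place of the group of 10 heavy atoms gives a 1.7-fold higher number from compound 2 to compound 4 (0.23 log units; within the scatter). The second end group and the carbon ring that carries it can therefore give way to a smaller ring with a ring nitrogen and no hydrogen-bond donors, with no shift that stands out from the usual scatter of repeated measurements. This single step thus gives no sign that the number for compound 2 depends on that second end group, and nothing shown here explains the result.

The step changes the ring and removes the end group together, so the contribution of each part cannot be separated from the compounds shown. On these data alone, it also remains open how this assay would respond to a plain phenyl ring, a pyridin-3-yl group, a carboxylic acid or an aminomethyl group on this same aromatic carbon, and whether a larger step could arise at this position at all.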